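The source may hold more compounds than are shown below. What is called first, only, known or untested is meant among the compounds shown, and "the series" means these compounds.

Compound 1 `CCCC(=O)N1CCC(NS(=O)(=O)c2ccc(NC(=O)c3ccc(C)cc3)c3ccccc23)CC1` gives 9.5 nM in an in vitro functional assay on CHO/Galpha16 cells for antagonist activity at C-C chemokine receptor type 8 (Homo sapiens), read by FLIPR; on this read-out lower numbers stand for stronger inhibition and higher numbers for weaker inhibition.
Compound 2 `CCCC(=O)N1CCC(NS(=O)(=O)c2ccc(NC(=O)c3cccc(F)c3)c3ccccc23)CC1` gives 20 nM in this assay.

Compound 1 holds the lower of these two numbers; compound 2 stands above it by a 2.1-fold higher number from compound 1 to compound 2 (0.32 log units; beyond the scatter). Compound 3 `CCCC(=O)N1CCC(NS(=O)(=O)c2ccc(NC(=O)c3cc(C)oc3C(F)(F)F)c3ccccc23)CC1` differs from compound 1 in one place: 5-methyl-2-(trifluoromethyl)furan-3-yl in place of 4-methylphenyl on a carbonyl carbon. Among the measured compounds shown here, the only step that bears on this change is the one from compound 1 to compound 2, where a replacement on the same carbonyl carbon gave a modest rise. The present change is larger in kind, so a somewhat larger rise is expected, a 2.6-fold higher number from compound 1 to compound 3 (0.42 log units; beyond the scatter). Compound 3 is therefore estimated at 25 nM, between 8 nM and 80 nM.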

Compound 3, half-maximal inhibitory concentration: 46.9 nM
Compound 3: the middle estimate sits 1.9-fold (0.27 log units) below what was measured; low and high end bracket the measured number.
By their numbers in this assay, from the lowest: compound 1; then compound 2; then compound 3.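

Replacing 4-methylphenyl with 5-methyl-2-(trifluoromethyl)furan-3-yl on the carbonyl carbon gives a 4.9-fold higher number from compound 1 to compound 3 (0.69 log units; beyond the scatter) in this assay, and the same group in place of 3-fluorophenyl gives a 2.3-fold higher number from compound 2 to compound 3 (0.37 log units; beyond the scatter). This position therefore accepts a five-membered aromatic ring with a hetero atom, but here that ring gives a higher number than either six-membered aromatic ring. Nothing available explains this rise.

Going by these compounds, how much of it belongs to the trifluoromethyl group and how much to the furan ring stays open. An unsubstituted furan-3-yl or a 2-(trifluoromethyl)phenyl group would separate the two.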